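The source may hold more compounds than are shown below. What is called first, only, known or untested is meant among the compounds shown, and "the series" means these compounds.

Measured compounds in a functional assay on OVCAR-3 cells (Homo sapiens) for inhibition, read by sulforhodamine B assay, with a stated time of 48 h; on this read-out lower numbers stand for stronger inhibition of growth and higher numbers for weaker inhibition of growth:
- compound 1 `COc1ccc(/C=C/C2CC(=O)C=CO2)cc1OC`: 74.3 uM
- compound 2 `COc1cc(/C=C/C2CC(=O)C=CO2)cc(OC)c1OC`: 85.4 uM
- compound 3 `O=C1C=CCC(/C=C/c2ccccc2C(F)(F)F)O1`: 296 uM

Compound 2 holds the second highest of the three numbers. Going by the values given here, its nearest neighbour is compound 1, whose number sits within the scatter of that of compound 2, so the two cannot be ordered; the one step between them, a 1.1-fold higher number from compound 1 to compound 2 (0.06 log units; within the scatter), confirms this. Compound 3 stands furthest away, with a higher number than that of compound 2, a gap beyond the scatter.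

Compound 4 `COc1cc(/C=C/C2CC=CC(=O)O2)cc(OC)c1OC` has not yet been measured. It differs from compound 2 in one place: a group of 7 heavy atoms (5 carbon, 2 oxygen; one six-membered non-aromatic ring with 1 hetero atom) in place of a group of 7 heavy atoms (5 carbon, 2 oxygen; one six-membered non-aromatic ring with 1 hetero atom), on a double-bonded chain carbon bound to a double-bonded chain carbon. The two compounds share the same atoms, joined differently.

Among the compounds with values here, the only measured step, from compound 1 to compound 2, concerns a methoxy group on an aromatic carbon and says nothing about a rearrangement of the six-membered non-aromatic ring. Within the data shown here, no measured pair bears on the change from compound 2 to compound 4. Without a comparable step, the working expectation is no change beyond the scatter, with a wide allowance in either direction.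

Compound 4 is therefore estimated at 85 uM, with a range from 35 uM to 210 uM, which amounts to an expected step of a 1.0-fold lower number from compound 2 to compound 4 (0.00 log units; within the scatter).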

Compound 4, concentration for growth inhibition (reported as GI): 44.9 uM
Compound 4: middle estimate off by 1.9-fold (0.28 log units), on the high side, and the stated range covers the measured number.
By their numbers in this assay, from the lowest: compounds 4, 1 and 2 (each within the scatter of the next); then compound 3.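

In this assay, going by these compounds alone, the change at this place, on a double-bonded chain carbon bound to a double-bonded chain carbon, is read for the first time, and it gives a 1.9-fold lower number from compound 2 to compound 4 (0.28 log units; within the scatter). The atoms stay the same and only their joining differs, and the counts of double bonds outside aromatic rings, hydrogen-bond donors and hydrogen-bond acceptors are also the same in the group that leaves and the group that enters, so with this aromatic substitution the two ring arrangements cannot be ordered. No measurement accompanies this result that could say what lies behind the number.

Compound 3 carries the same group as compound 4 but differs from it on the aromatic ring in more than one place, so whether the step holds with other aromatic substitution remains unsettled. Also open, on these data alone, is how the series would respond to an amine or a carboxylic acid on the aromatic ring, or to a longer chain in place of the double-bonded chain, and whether any such change would give a step beyond the scatter in this read-out.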